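A few compounds are considered here, and "the series" means these few. Any claim that something is new, unique, unknown or untested is made for them only; others in the source may bear on it.

Of the compounds shown here, three that share a core have been measured in a functional assay on HCT-15 cells (Homo sapiens) for cytotoxicity, read by ELISA, with a stated time of 2 days; on this read-out higher numbers stand for weaker inhibition and lower numbers for stronger inhibition. In this test, compound 1 `Oc1ccccc1-c1cc(-c2ccccc2)nc(-c2ccco2)c1` gives 2500 nM, compound 2 `Oc1cccc(-c2cc(-c3ccccc3)nc(-c3ccccc3)c2)c1` gives 18000 nM and compound 3 `Oc1cccc(-c2cc(-c3ccccc3)nc(-c3ccsc3)c2)c1` gives 24600 nM. Compound 3 therefore sits with compound 2 at the high, weaker end of this small set, while compound 1 has a clearly lower number.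

The next change turns compound 3 into compound 4 `Oc1cccc(-c2cc(-c3ccccc3)nc(-c3ccco3)c2)c1`, with furan-2-yl in place of thiophen-3-yl on an aromatic carbon. The group sits on an aromatic carbon, next to the ring nitrogen. Among the measured compounds shown here, one measured step bears directly on this place: a 1.4-fold higher number from compound 2 to compound 3 (0.14 log units; within the scatter). That swap of phenyl for thiophen-3-yl stays within the scatter, so exchanging this ring has so far shown no real effect. Compound 1 also carries furan-2-yl, but it has no 3-hydroxyphenyl group, so its 2500 nM is only a loose hint towards lower numbers. A small step downward in this assay is therefore expected, near the edge of the scatter. The expected change is a 2.1-fold lower number from compound 3 to compound 4 (0.31 log units; beyond the scatter). For compound 4 the estimated value is 12000 nM, within an expected range of 4000 nM to 30000 nM.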

Compound 4, half-maximal inhibitory concentration: 13900 nM
Estimate against measurement, compound 4: 1.2-fold (0.06 log units) below; the measured number falls inside the stated range.
By their numbers in this assay, from the lowest: compound 1; then compounds 4, 2 and 3 (each within the scatter of the next).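

In this assay, the three rings tried at this carbon cannot be told apart: a 1.8-fold lower number from compound 3 to compound 4 (0.25 log units; within the scatter) and a 1.3-fold lower number from compound 2 to compound 4 (0.11 log units; within the scatter) both stay within the scatter, so exchanging one of these rings for another has shown no real effect. Among the compounds shown here, the only clear change comes from the other side of the shared core, with furan-2-yl held constant and 3-hydroxyphenyl in place of 2-hydroxyphenyl: a 5.6-fold higher number from compound 1 to compound 4 (0.75 log units; beyond the scatter). Compound 4 carries furan-2-yl as well, so the lower number of compound 1 goes with its 2-hydroxyphenyl group and not with that ring.

Nothing measured alongside these numbers explains either result. On these data alone, it remains open whether a group of a different kind at this carbon, such as an amine, a carboxylic acid or a longer alkyl chain, would move the number, and whether the 2-hydroxyphenyl group would keep its lower number with phenyl or thiophen-3-yl in place of furan-2-yl.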